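Chloro for hydrogen on the core of compound 1

The source may report more compounds than this note shows. Statements on the series, on what has been measured and on what is new or still open speak of the compounds shown alone.

The shared core carries a tetrazole on a bicyclic ring system, shown for compound 1 as `O=c1c(-c2nn[nH]n2)c[nH]c2ccccc12`. Among the compounds with values here, in a functional assay on the whole organism (strain Sprague-Dawley) for inhibition, with Rattus norvegicus as the target (a lower number here means that less compound is needed, a higher number that more compound is needed for the effect), compound 1 gives 1.25 mg/kg, the only plain number among the values shown. Compound 2, `CCc1ccc2c(=O)c(-c3nn[nH]n3)c[nH]c2c1`, carries an ethyl group on the aromatic carbon. In this assay compound 2 gives < 5 mg/kg, which is a limit of the assay and not a number. The step that the limit leaves unreadable from compound 1 to compound 2 is therefore unreadable because of the limit of < 5 mg/kg in this assay, at which 1 of the 2 values shown sits.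

Compound 3, `O=c1c(-c2nn[nH]n2)c[nH]c2c(Cl)cccc12`, differs from compound 1 by chloro in place of hydrogen on an aromatic carbon. Within the data shown here, no measured step with a readable size touches this change, so there is nothing to suggest a shift beyond the usual scatter in either direction. Compound 3 is therefore expected to stand close to compound 1, with an estimated step of no change at the digits printed from compound 1 to compound 3 (within the scatter). The value expected for compound 3 is 1.25 mg/kg, estimated to lie between 0.5 mg/kg and 3.5 mg/kg.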

Compound 3, minimum effective dose: 0.078 mg/kg
Compound 3: middle estimate off by 16-fold (1.20 log units), on the high side, and the stated range ends above it.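

In this assay, chloro in place of hydrogen on an aromatic carbon, ortho to a fused ring, brings a 16-fold lower number from compound 1 to compound 3 (1.20 log units; beyond the scatter) with only one heavy atom added. This position on the core of compound 1 is therefore sensitive: a group with no ring, no net charge and no hydrogen-bond donors or acceptors is enough to move the dose beyond the scatter. No measurement shown here accounts for why chloro has this effect.

As far as these compounds go, whether bromo, methoxy or an amine at this same position would act as chloro does remains open, as does what chloro would do on the other aromatic carbons of the core. The step to compound 2 cannot be read, so no size is known for a group elsewhere on this ring: the limit of < 5 mg/kg in this assay, at which 1 of the 3 values shown sits.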